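This account rests on a few compounds, and the source may have more. Where it says the series, first, only, none or still open, it means among the compounds named here.

Values so far in a physicochemical assay for solubility, measured as kinetic solubility, at pH 2; a higher number here means a more soluble compound, a lower number a less soluble compound
- Compound 1 `CC(C)[C@H](C[C@H]1CCNC1=O)c1ccc(-c2ccc3cccc(F)c3c2)[nH]c1=O` gives 38300 nM
- Compound 2 `CCC(CC)(c1nnc[nH]1)c1ccc(-c2ccc3cccc(F)c3c2)[nH]c1=O` gives 28500 nM
- Compound 3 `CC(C)C(c1nnc[nH]1)c1ccc(-c2ccc3cccc(F)c3c2)[nH]c1=O` gives 31800 nM

Compound 1 (38300 nM) stands within the usual scatter of both compound 2 and compound 3, so these three numbers carry no order. Compound 4 `CC(C)[C@@H](C[C@H]1CCNC1=O)c1ccc(-c2ccc3cccc(F)c3c2)[nH]c1=O` awaits measurement. Its difference from compound 1 is one of configuration only (the two compounds have the same atoms and bonds and differ only in configuration as drawn: 1 of 2 stereo elements differ; a stereocentre at a saturated chain carbon is drawn S in compound 1 and R in compound 4): a stereocentre at a saturated chain carbon is drawn S in compound 1 and R in compound 4.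

For the measured compounds named here, the series holds no measured pair that differs in one place, so no direct measure of such a change exists. Compound 2 (28500 nM) and compound 3 (31800 nM) differ from compound 1 in more than configuration, and their values still lie within its scatter. No step beyond the scatter is therefore expected in this assay, and no direction is favoured. The estimated step (a 1.2-fold lower number from compound 1 to compound 4 (0.06 log units; within the scatter)) is expected to stay within the scatter. The estimate for compound 4 is 33000 nM with an expected range from 17000 nM to 60000 nM.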

Compound 4, solubility: 25400 nM
Compound 4: middle estimate off by 1.3-fold (0.11 log units), on the high side, and the stated range covers the measured number.
By their numbers in this assay, from the lowest: compounds 4, 2, 3 and 1 (each within the scatter of the next).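

Compound 1 and compound 4 give the series its first direct reading at a single place, the stereocentre at a saturated chain carbon. In this assay, going from S to R gives a 1.5-fold lower number from compound 1 to compound 4 (0.18 log units; within the scatter) and so shows no effect of this configuration that can be told apart from repeat measurement. The reading is a clean one, with no other structural change to account for the two numbers: the fact that compounds 1 and 4 differ only in the configuration as drawn.

The second stereo element is drawn the same way in both compounds, so its configuration remains unread. Also open, going by these compounds, is whether an amine or a carboxylic acid on the chain at this carbon would give a step beyond the scatter, and whether the configuration would then count for more.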